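A few compounds are considered here, and "the series" means these few. Any claim that something is new, unique, unknown or untested is made for them only; others in the source may bear on it.

The series is built on the shared core of compound 1 `COc1ccc(C(=O)Oc2cc3c(cc2C)[C@@H](C(C)C)CC=C3C)cc1`, an ester in which a 4-methoxyphenyl group sits on the carbonyl carbon. Within the data shown here, in a functional assay on K562 cells (Homo sapiens) for antiproliferative activity, read by sulforhodamine B assay, with a stated time of 48 h, tested at 50 uM (on this read-out higher numbers stand for more inhibition at the one concentration tested (going by the name of the read-out) and lower numbers for less inhibition), compound 1 gives 46.5%, and this is the only number in the set: compound 2 `COc1cccc(C(=O)Oc2cc3c(cc2C)[C@@H](C(C)C)CC=C3C)c1` is reported as "not active" (no number reported) and compound 3 `Cc1cc2c(C(C)C)ccc(C)c2cc1OC(=O)c1cccc(C(F)(F)F)c1` is reported as "not active" (no number reported), neither with a figure, so compound 1 stands alone as the one member with a measured degree of inhibition.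

Compound 4 `CC1=CC[C@H](C(C)C)c2cc(C)c(OC(=O)c3cccc(C)c3)cc21` differs from compound 1 in a single place, (3-methylphenyl in place of 4-methoxyphenyl on a carbonyl carbon). Among the measured compounds shown here, no pair of measured compounds differing in one place is available, so the size of this step cannot be read off from earlier data. Because compound 2 in this assay came back with "not active" (no number reported) and compound 3 came back with "not active" (no number reported), a step downward rather than upward is expected of compound 4, of a size beyond the usual scatter, though a result within the scatter of compound 1 cannot be excluded. Compound 4 is therefore estimated to show 25% in this assay, within a range from 5% to 45%, which means an expected step of a number 21.5 percentage points lower from compound 1 to compound 4 (beyond the scatter).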

Compound 4, a percentage reported as inhibition, at one concentration (the size of the read-out at that concentration, not a potency): "not active" (no number reported)
The entry for compound 4 holds no number, and the estimate cannot be compared.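

Among these compounds, compound 4, like compound 2 and compound 3, is reported as not active in this assay with no figure, so no step from compound 1 to compound 4 can be read. The compounds shown leave open how much inhibition, if any, these three entries retain. No measurement shown bears on the reason for this result.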